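Working notes: lengthening the side chain of compound 3

The source may hold more compounds than are shown below. What is called first, only, known or untested is meant among the compounds shown, and "the series" means these compounds.

- compound 1 `CCCCCc1cn(C/C=C(\C)CCC=C(C)C)nn1`: 5.45
- compound 2 `CCCCCCCCc1cn(C/C=C(\C)CC/C=C(\C)CCC=C(C)C)nn1`: 8.76
- compound 3 `CCCCCCCCc1cn(CC=C(C)C)nn1`: 4.92

In a physicochemical assay for lipophilicity, measured as octanol-water partition (on this read-out higher numbers stand for higher lipophilicity and lower numbers for lower lipophilicity), compound 3 stands lowest of the three at 4.92, with compound 1 nearest and compound 2 furthest, both beyond the scatter. Compound 4 `CCCCCCCCc1cn(C/C=C(\C)CCC=C(C)C)nn1` differs from compound 3 by one change: 3-methylbut-2-en-1-yl in place of hydrogen on a saturated chain carbon bound to a double-bonded chain carbon. Within the data shown here, no measured pair differs in one place, so the size of the step can only be inferred indirectly. Compound 2 carries a longer form of the same side chain and reads 8.76. A rise well beyond the scatter in this assay, part of the way up to that value, is expected, estimated as a number 1.93 log units higher from compound 3 to compound 4 (beyond the scatter). For compound 4 the estimated value is 6.85, with an expected range of 6.4 to 7.3.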

Compound 4, partition coefficient: 6.92
Compound 4: middle estimate off by 0.07 log units, on the low side; low and high end bracket the measured number.
By their numbers in this assay, from the lowest: compound 3; then compound 1; then compound 4; then compound 2.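

In this assay, 3-methylbut-2-en-1-yl in place of hydrogen now has a directly read step, a number 2.00 log units higher from compound 3 to compound 4 (beyond the scatter). Hydrogen in place of the same group on the longer side chain gives a number 1.84 log units lower from compound 2 to compound 4 (beyond the scatter), so both steps for this group are large. Propyl in place of hydrogen on a saturated chain carbon, five bonds along the chain from an aromatic carbon, gives a number 1.47 log units higher from compound 1 to compound 4 (beyond the scatter). Nothing available explains the size of these steps. On these data alone, how an amine or a carboxylic acid at this position would read in this assay remains open.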